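The source may report more compounds than this note shows. Statements on the series, on what has been measured and on what is new or still open speak of the compounds shown alone.

Measured compounds:
compound 1 `COc1ccccc1/C=C/C(=O)OC/C=C/c1cc(OC)c(OC)cc1OC` — 100%
compound 2 `COc1cc(OC)c(OC)cc1/C=C/COC(=O)/C=C/c1cc(OC)c(OC)c(OC)c1OC` — 75%
compound 3 `COc1cc(OC)c(OC)cc1/C=C/COC(=O)/C=C/c1cccc(Br)c1` — 100%

In a functional assay on the whole organism (strain Kunming) with Mus musculus as the target, with a stated time of 0.5 h, at a dose of 100 mg/kg by the intraperitoneal route (a higher number here means a weaker effect of the compound at the dose given, a lower number a stronger effect), compound 3 gives 100%, level with compound 1 at the digits shown, and these two sit together at the top of the three numbers. Compound 2 gives 75%, a lower number that lies beyond the scatter. The unmeasured compound 4 `COc1ccc(/C=C/C(=O)OC/C=C/c2cc(OC)c(OC)cc2OC)cc1` differs from compound 3 in one place: 4-methoxyphenyl in place of 3-bromophenyl on a double-bonded chain carbon bound to a double-bonded chain carbon. For the measured compounds named here, the only measured step at this same place is no change at the digits printed from compound 1 to compound 3 (within the scatter), where one aryl group replaced another without any movement beyond the scatter. Swapping one aryl group for another here is therefore expected to leave the read-out essentially where compound 3 stands, with the step of a number 3 percentage points lower from compound 3 to compound 4 (within the scatter) expected to stay within the scatter. Compound 4 is estimated to give 97%, between 85% and 100%.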

Compound 4, a percentage reported as activity, at one dose (the size of the read-out at that dose, not a potency): 100%
Beside the measured number, compound 4's estimate is 3 percentage points below it; low and high end bracket the measured number.
By their numbers in this assay, from the lowest: compound 2; then compounds 1, 3 and 4 (each within the scatter of the next).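

In this assay, this place on the chain now holds a third aryl group, and the read-out gives no change at the digits printed from compound 3 to compound 4 (within the scatter) and no change at the digits printed from compound 1 to compound 4 (within the scatter). The 2-methoxyphenyl, 3-bromophenyl and 4-methoxyphenyl groups therefore read alike here, so neither exchanging bromine for methoxy nor using the 4-methoxyphenyl group in place of the 2-methoxyphenyl group separates these compounds at this dose. No supporting evidence explains this flat result. Going by these compounds, whether an aryl group bearing an amine or a carboxylic acid would move the number at this place remains open.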